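The compounds below may be only part of what the source reports. "The series", "measured", "known", "first", "only" and "open" are said of these compounds alone.

Among the compounds with values here, compound 2 `Cc1ccc(/C=C/C(=O)c2sc(NC(=O)c3ccc(F)cc3)nc2C)cc1` and compound 1 `COc1ccc(C(=O)Nc2nc(C)c(C(=O)/C=C/c3ccc(F)cc3)s2)cc1` share a core and differ in two places at once, so no single step between them can be read. In an assay for inhibition of Polyunsaturated fatty acid 5-lipoxygenase (Homo sapiens), read by spectrophotometry, in the presence of a further agent that is not named here (a lower number here means a stronger inhibitor, a higher number a weaker inhibitor), compound 2 gives 540 nM. In this assay compound 1 gives 560 nM. Compound 2 has the lowest of the two numbers, but the gap to compound 1 is within the scatter, so the two cannot be ordered. Compound 3 `COc1ccc(C(=O)Nc2nc(C)c(C(=O)/C=C/c3ccc(C)cc3)s2)cc1` is made from compound 2 by one change: methoxy in place of fluoro on an aromatic carbon. Within the data shown here, no measured pair shows this change alone. Since compound 1, which carries the methoxy at that same place, gives 560 nM, no step beyond the scatter in this assay is expected. For compound 3 the expected step is a 1.0-fold higher number from compound 2 to compound 3 (0.01 log units; within the scatter), and its value in this assay is estimated at 550 nM, in a range from 250 nM to 1200 nM.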

Compound 3, half-maximal inhibitory concentration: 80 nM
Compound 3: the middle estimate sits 6.9-fold (0.84 log units) above what was measured; the whole stated range lies above it.
By their numbers in this assay, from the lowest: compound 3; then compounds 2 and 1 (each within the scatter of the next).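

In this assay, 4-fluorophenyl gives way to 4-methoxyphenyl, para to a large group, and this single change brings a 6.8-fold lower number from compound 2 to compound 3 (0.83 log units; beyond the scatter), so this position clearly responds to the group it carries when the methyl stays at the other end of the molecule. Methyl in place of fluoro on the other aromatic ring, with the methoxy held fixed, brings a step of similar size, a 7.0-fold lower number from compound 1 to compound 3 (0.85 log units; beyond the scatter), and neither step could be seen from compound 1 and compound 2, which differ in two places at once. Nothing offered here explains either step.

The compounds shown leave open whether the methoxy step would also appear with fluoro rather than methyl on the other ring. They also leave open how a hydroxyl, an amine or a longer ether such as ethoxy would read at the same position.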